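Estimating Compound 4 from Three Measured Analogues

This account rests on a few compounds, and the source may have more. Where it says the series, first, only, none or still open, it means among the compounds named here.

Compound 1, `CC(C)=CCC1Cc2c(OCCCNC(=O)c3ccc([N+](=O)[O-])cc3)cc(=O)n(CCCO)c2CC1(C)C`, gives 9.1% in a functional assay on PANC-1 cells (Homo sapiens) for inhibition, read by MTT assay, with a stated time of 24 h, tested at 10 uM; on this read-out higher numbers stand for more inhibition at the one concentration tested (going by the name of the read-out) and lower numbers for less inhibition.
Compound 2, `COc1ccc(OCCCOc2cc(=O)n(CCCO)c3c2CC(CC=C(C)C)C(C)(C)C3)cc1`, gives 4.1% in this assay.
Compound 3, `CC(C)=CCC/C(C)=C/CC1Cc2c(OCCCNC(=O)c3ccc([N+](=O)[O-])cc3)cc(=O)n(CCCO)c2CC1(C)C`, gives 6.5% in this assay.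

All three measured compounds sit low on this read-out, and no two of them are separated by more than the usual scatter. Compound 1 and compound 2 differ in one place: 4-methoxyphenoxy in place of ((4-nitrophenyl)carbonyl)amino on a saturated chain carbon, three bonds along the chain from an oxygen on an aromatic ring. The step that accompanies this change is a number 5 percentage points lower from compound 1 to compound 2 (within the scatter). Compound 1 and compound 3 differ only in their cores: 3-methylbut-2-en-1-yl in place of hydrogen on a saturated chain carbon bound to a double-bonded chain carbon. The step here is a number 2.6 percentage points lower from compound 1 to compound 3 (within the scatter). Among the three measured numbers compound 3 stands second, yet its distance to each neighbour is within the scatter, so no order can be read from it.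

Compound 4, `COc1ccc(OCCCOc2cc(=O)n(CCCO)c3c2CC(C/C=C(\C)CCC=C(C)C)C(C)(C)C3)cc1`, has not yet been measured. It is related to compound 3 by 4-methoxyphenoxy in place of ((4-nitrophenyl)carbonyl)amino on a saturated chain carbon, three bonds along the chain from an oxygen on an aromatic ring. This is the same change as from compound 1 to compound 2, made at a place that reads the same word for word; what differs is only the core carrying it, as described above.

Because the step of a number 5 percentage points lower from compound 1 to compound 2 (within the scatter) stayed within the scatter, a step of similar size is expected for compound 4, namely a number 4.5 percentage points lower from compound 3 to compound 4 (within the scatter). Compound 4 is thus estimated at 2%, with a likely range from -7% to 11%.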

Compound 4, a percentage reported as inhibition, at one concentration (the size of the read-out at that concentration, not a potency): 0%
Beside the measured number, compound 4's estimate is 2 percentage points above it; the measured number falls inside the stated range.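

On the core of compound 3, 4-methoxyphenoxy in place of ((4-nitrophenyl)carbonyl)amino comes with a number 6.5 percentage points lower from compound 3 to compound 4 (within the scatter), and this step agrees with the one seen on the core of compound 1: the same change on two cores in this assay, a number 5 percentage points lower (within the scatter) from compound 1 to compound 2 and a number 6.5 percentage points lower (within the scatter) from compound 3 to compound 4, 1.5 percentage points apart, within the scatter of two such steps. The other change, 3-methylbut-2-en-1-yl in place of hydrogen on a saturated chain carbon bound to a double-bonded chain carbon, gives a number 4.1 percentage points lower from compound 2 to compound 4 (within the scatter) and likewise agrees with its earlier counterpart: the same change on two cores in this assay, a number 2.6 percentage points lower (within the scatter) from compound 1 to compound 3 and a number 4.1 percentage points lower (within the scatter) from compound 2 to compound 4, 1.5 percentage points apart, within the scatter of two such steps. Within the data shown here, every one of these steps lies within the scatter, however, and all four compounds sit low on this read-out; the agreement therefore shows only that neither change stands clear of the scatter on either core, not that a real effect of either change carries over from one core to another.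

The compounds shown leave open whether a different group in place of ((4-nitrophenyl)carbonyl)amino on that saturated chain carbon, such as an amine or a carboxylic acid, would give a number that stands clear of the scatter in this assay. They also leave open whether the two changes would still give matching steps on a compound that reads high in this assay.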